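A few compounds are considered here, and "the series" means these few. Any claim that something is new, unique, unknown or untested is made for them only; others in the source may bear on it.

Measured compounds:
compound 1 `CC(C)(C)OC(=O)NCCC[C@@H]1N=C2C[C@@H]3C[C@@H](C3(C)C)[C@]2(C)OC1=O`: > 1200000 nM
compound 2 `CC(C)(C)OC(=O)NCCCC[C@H]1N=C2C[C@H]3C[C@H](C3(C)C)[C@@]2(C)OC1=O`: > 1300000 nM

In an ADME assay on MCF-10A cells (Homo sapiens) for antiproliferative activity, read by sulforhodamine B assay, with a stated time of 48 h (on this read-out higher numbers stand for weaker inhibition and lower numbers for stronger inhibition), compound 1 gives > 1200000 nM, which is a limit of the assay rather than a number (the limit of > 1200000 nM in this assay, at which 1 of the 2 values shown sits). In this assay compound 2 gives > 1300000 nM, again only a limit (the limit of > 1300000 nM in this assay, at which 1 of the 2 values shown sits), so compound 2 stands with compound 1 among values that are limits and nothing more. Compound 3 `CC(C)(C)OC(=O)NCCCC[C@@H]1N=C2C[C@@H]3C[C@@H](C3(C)C)[C@]2(C)OC1=O` differs from compound 2 in that (the two compounds have the same atoms and bonds and differ only in configuration as drawn: 4 of 4 stereo elements differ (all stereocentres are inverted: mirror images); a stereocentre at a saturated ring carbon is drawn R in compound 2 and S in compound 3; a stereocentre at a saturated ring carbon is drawn R in compound 2 and S in compound 3; a stereocentre at a saturated ring carbon is drawn R in compound 2 and S in compound 3; a stereocentre at a saturated ring carbon is drawn R in compound 2 and S in compound 3). Among the measured compounds shown here, no step between measured compounds is recorded; with both recorded values sitting at limits, the expected step of a number no higher from compound 2 to compound 3 (the limit leaves the size open) is none beyond the scatter. Compound 3 is therefore expected to give 1300000 nM, between 300000 nM and 5000000 nM.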

Compound 3, half-maximal inhibitory concentration: > 800000 nM
Compound 3: a limit, no number; the forecaster's own chance of this, stated with the estimate: 85%; the middle value lies beyond the limit too.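

Compounds 1, 2 and 3 are all recorded only as limits in this assay, so the steps from compound 2 to compound 3 and from compound 1 to compound 3 cannot be read. On these data alone, whether inverting all stereocentres, or ((tert-butoxycarbonyl)amino)methyl in place of (tert-butoxycarbonyl)amino, changes the result in this assay stays open.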